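Swapping the sugar's amide for a hydroxymethyl group

The compounds below may be only part of what the source reports. "The series", "measured", "known", "first", "only" and "open" are said of these compounds alone.

Compound 2 `CCCCc1cn(-c2nc(NC)c3ncn([C@@H]4O[C@H](C(=O)NCC)[C@@H](O)[C@H]4O)c3n2)nn1` gives the lowest number of the two measured compounds in an assay on CHO cells for displacement of a labelled ligand from adenosine receptor A3 (Homo sapiens) (a lower number here means a stronger inhibitor, a higher number a weaker inhibitor), at 5.6 nM. Compound 1 `CNc1nc(-n2cc(-c3ccccc3)nn2)nc2c1ncn2[C@@H]1O[C@H](CO)[C@@H](O)[C@H]1O`, which already carries a hydroxymethyl on its sugar ring, gives 14.9 nM in this assay. Compound 3 `CCCCc1cn(-c2nc(NC)c3ncn([C@@H]4O[C@H](CO)[C@@H](O)[C@H]4O)c3n2)nn1` differs from compound 2 by hydroxymethyl in place of ethylcarbamoyl on a saturated ring carbon. For the measured compounds named here, no directly comparable step is on record, so the expected change is a modest loss of binding: the estimated step is a 4.5-fold higher number from compound 2 to compound 3 (0.65 log units; beyond the scatter). Compound 3 is therefore expected to give about 25 nM in this assay, within a range from 8 nM to 80 nM.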

Compound 3, inhibition constant: 11.7 nM
Estimate against measurement, compound 3: 2.1-fold (0.33 log units) above; measured number inside the range.
By their numbers in this assay, from the lowest: compound 2; then compounds 3 and 1 (each within the scatter of the next).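

In this assay the step of a 2.1-fold higher number from compound 2 to compound 3 (0.32 log units; beyond the scatter) shows that trading ethylcarbamoyl for hydroxymethyl on this saturated ring carbon costs only modest binding, so the longer amide group is not needed for nanomolar values in this butyl series. With hydroxymethyl in place, butyl in place of phenyl gives a 1.3-fold lower number from compound 1 to compound 3 (0.11 log units; within the scatter) and so separates the two groups no further than repeat measurements would. Nothing on record explains the modest loss at the ring carbon. As far as these compounds go, whether a carboxylic acid or an amine on this ring carbon would keep binding remains open. From the compounds shown here alone, whether butyl and phenyl also match alongside ethylcarbamoyl remains open too.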